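Methyl for trifluoromethyl on the amide aryl ring

This account rests on a few compounds, and the source may have more. Where it says the series, first, only, none or still open, it means among the compounds named here.

Measured compounds:
compound 1, `NC(=O)c1c(NC(=O)c2ccc(C(F)(F)F)cc2)sc2c1CCN(Cc1ccc(Cl)cc1Cl)C2`, 10900 nM
compound 2, `Cc1ccc(C(=O)Nc2sc3c(c2C(N)=O)CCN(Cc2ccc(Cl)cc2Cl)C3)cc1`, 25500 nM
compound 3, `NC(=O)c1c(NC(=O)c2ccccc2C(F)(F)F)sc2c1CCN(C(=S)Nc1ccccc1Cl)C2`, 21900 nM

All three were run in a functional assay on MKN-74 cells (Homo sapiens) for antiproliferative activity, with a stated time of 24 h; on this read-out higher numbers stand for weaker inhibition and lower numbers for stronger inhibition. Among the measured compounds shown here, the one single-point comparison that exists is between compound 1 and compound 2: the change is methyl in place of trifluoromethyl on an aromatic carbon and it gave a 2.3-fold higher number from compound 1 to compound 2 (0.37 log units; beyond the scatter). Compound 3 differs from compound 1 in more than one place, so the difference between the two cores is not broken down here; compound 3 sits among the three numbers with a value that lies within the scatter of both compound 1 and compound 2, so no order among them is claimed.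

Compound 4, `Cc1ccccc1C(=O)Nc1sc2c(c1C(N)=O)CCN(C(=S)Nc1ccccc1Cl)C2`, has not yet been measured. Relative to compound 3 it carries methyl in place of trifluoromethyl on an aromatic carbon. For the measured compounds named here, this is the same kind of change as the one from compound 1 to compound 2, but not the same: in that pair the place was "para to a large group", whereas here it is "ortho to a large group". That difference in surroundings, plus the fact that compound 3 rests on a different core, means the earlier step is only a loose guide.

In this assay compound 4 is expected to give 35000 nM, with a plausible range of 15000 nM to 80000 nM. That amounts to an expected step of a 1.6-fold higher number from compound 3 to compound 4 (0.20 log units; within the scatter), set beside the measured 2.3-fold higher number from compound 1 to compound 2 (0.37 log units; beyond the scatter) and leaning toward a smaller shift because a 2.3-fold higher number from compound 1 to compound 2 (0.37 log units; beyond the scatter) is modest and was measured at a different place on the ring.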

Compound 4, half-maximal inhibitory concentration: 11000 nM
For compound 4 the middle estimate is 3.2-fold (0.50 log units) above the measured one; measured number below the stated range.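

In this assay, methyl in place of trifluoromethyl on the amide aryl ring gave a 2.0-fold lower number from compound 3 to compound 4 (0.30 log units; within the scatter), so on this core the replacement cannot be told apart from repeat-measurement scatter. Read beside the earlier pair, the step does not transfer as a fixed increment from one core to the other: the same change on two cores in this assay, a 2.3-fold higher number (0.37 log units; beyond the scatter) from compound 1 to compound 2 and a 2.0-fold lower number (0.30 log units; within the scatter) from compound 3 to compound 4, 4.7-fold (0.67 log units) apart, beyond the scatter of two such steps. Among the compounds shown here, this shows only that the earlier step should not be applied to the core of compound 3 as a correction of set size or direction; it does not show what drives the gap, since the two pairs differ in core and also in the place of the change, which in the newer pair is ortho to a large group, and each combination rests on a single pair.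

Still open, from the compounds shown here alone, is whether the swap behaves differently at one place on the ring when the core is held constant, or on the two cores when the place is held constant. Also open, going by these compounds, is how a methoxy group, an amine or a carboxylic acid on that same aromatic carbon would read on either core.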